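Chloro on the pyridinone ring: rat microsomal stability

This account rests on a few compounds, and the source may have more. Where it says the series, first, only, none or still open, it means among the compounds named here.

Compound 1 `CCCCc1[nH]c(=O)c(S(=O)(=O)c2ccc(-c3ccc(F)nc3)cc2)c(O)c1-c1c(OC)cccc1OC` has only "not determined" (no result reported) in an ADME assay on microsomes from liver (Rattus norvegicus) for metabolic stability, using NADPH, with a stated time of 10 min; on this read-out lower numbers stand for a less stable compound and higher numbers for a more stable compound. Among the measured compounds shown here, compound 2 `CCCCc1[nH]c(=O)c(S(=O)(=O)c2ccc(-n3ccccc3=O)cc2)c(O)c1-c1c(OC)cccc1OC` gives 100% in this assay, the only number in the set, so it stands at the top of the read-out with nothing to compare against. Compound 3 `CCCCc1[nH]c(=O)c(S(=O)(=O)c2ccc(-n3cc(Cl)ccc3=O)cc2)c(O)c1-c1c(OC)cccc1OC` differs from compound 2 by chloro in place of hydrogen on an aromatic carbon. For the measured compounds named here, with no measured step of this kind, the expected change from compound 2 to compound 3 is a number 5 percentage points lower from compound 2 to compound 3 (within the scatter), none beyond the scatter, perhaps a slight drop. Compound 3 is estimated at 95%, within 78% to 100%.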

Compound 3, percent of the compound remaining: 72%
For compound 3 the middle estimate is 23 percentage points above the measured one; the whole stated range lies above it.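

Chloro in place of hydrogen at this position, two atoms from the ring nitrogen, gives a number 28 percentage points lower from compound 2 to compound 3 (beyond the scatter) in this assay and so moves the read-out toward a less stable compound. This single heavy atom is therefore enough to change the result at this position, which a lone value could not show. No available data account for the step.

Going by these compounds, whether a fluoro, methyl or methoxy group at this same position would give a step of similar size remains open. So does the effect of chloro on the other carbons of this ring.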